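Chloro and methyl substitution on the hydroxyphenyl diketone series

The source may hold more compounds than are shown below. What is called first, only, known or untested is meant among the compounds shown, and "the series" means these compounds.

Of the compounds shown here, three of a shared core have been measured in an ADME assay on PANC-1 cells (Homo sapiens) for inhibition, read by MTT assay, with a stated time of 90 h; on this read-out lower numbers stand for stronger inhibition of growth and higher numbers for weaker inhibition of growth. Compound 1 `O=C(CC(=O)c1cc(Cl)ccc1O)c1cc2ccccc2s1` gives 8.44 ug/mL and stands lowest of the three, though compound 3 `Cc1ccc(C(=O)CC(=O)c2cc3ccccc3s2)c(O)c1` with 9.24 ug/mL lies within the scatter of it. How the core of compound 1 and the core of compound 3 differ is not broken down here. Compound 2 `Cc1cc(O)c(C(=O)CC(=O)c2cc3ccccc3s2)cc1Cl` gives 20.4 ug/mL; the step of a 2.4-fold higher number from compound 1 to compound 2 (0.38 log units; beyond the scatter) is methyl in place of hydrogen on an aromatic carbon, and the step of a 2.2-fold higher number from compound 3 to compound 2 (0.34 log units; beyond the scatter) is chloro in place of hydrogen on an aromatic carbon.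

Compound 4 `O=C(CC(=O)c1cc(Cl)cc(Cl)c1O)c1cc2ccccc2s1` has not yet been measured. It carries the change (chloro in place of hydrogen on an aromatic carbon), the same kind of change as from compound 3 to compound 2, but the place is not the same: in compound 4 the entering chloro sits ortho to a hydroxy group and meta to a chloro group, whereas in compound 2 it sits ortho to a methyl group and para to a hydroxy group. For the measured compounds named here, with only one measured example of this kind of change, the expectation rests on that single step: a modest rise is expected, a 1.8-fold higher number from compound 1 to compound 4 (0.25 log units; within the scatter), because compound 2 showed a 2.2-fold higher number from compound 3 to compound 2 (0.34 log units; beyond the scatter). Compound 4 is therefore estimated at 15 ug/mL in this assay, with the range 7 ug/mL to 32 ug/mL allowing for the different surroundings of the new chloro.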

Compound 4, concentration for 50% growth inhibition: 26.2 ug/mL
Beside the measured number, compound 4's estimate is 1.7-fold (0.24 log units) below it, and the stated range covers the measured number.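

The entering chloro again moves the number towards weaker inhibition of growth in this assay, here with a 3.1-fold higher number from compound 1 to compound 4 (0.49 log units; beyond the scatter). Across the two cores the change points the same way, and its size does not separate them: the same change on two cores in this assay, a 2.2-fold higher number (0.34 log units; beyond the scatter) from compound 3 to compound 2 and a 3.1-fold higher number (0.49 log units; beyond the scatter) from compound 1 to compound 4, 1.4-fold (0.15 log units) apart, within the scatter of two such steps. For the compounds shown here, this supports carrying the change between these two cores as a modest rise, but it rests on only two steps, and the entering chloro does not occupy the same place in them, so the effect of the core cannot be told apart from that of the place, and nothing follows for any other core.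

Open, from the compounds shown here alone, is whether the rise is particular to chloro or also appears with a fluoro, a bromo or a trifluoromethyl group in the place ortho to the hydroxy group and meta to the chloro group of compound 4. Also open, going by these compounds, is how the same change behaves when the hydroxy group gives way to a methoxy group or an amine, or when a carboxylic acid or a longer chain stands on the same ring.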